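Indazole sulfonamide piperidine amides: maximal response at muscarinic M5

The source may report more compounds than this note shows. Statements on the series, on what has been measured and on what is new or still open speak of the compounds shown alone.

Measured so far:
compound 1, `CCN(Cc1ccccc1)C(=O)C1CCN(S(=O)(=O)c2ccc3[nH]ncc3c2)CC1`: 86%
compound 2, `CCN(Cc1ccccc1Cl)C(=O)C1CCN(S(=O)(=O)c2ccc3cn[nH]c3c2)CC1`: 93%

In a functional assay on CHO cells for positive allosteric modulation of muscarinic acetylcholine receptor M5 (Homo sapiens), read by calcium flux (on this read-out higher numbers stand for larger maximal responses and lower numbers for smaller maximal responses), compound 1 reaches 86% and compound 2 reaches 93%. Compound 2 holds the higher of the two numbers, but the gap to compound 1 lies within the usual scatter, so the two cannot be told apart on this read-out. Among the compounds with values here, no pair of measured compounds differs in one place only, so no step size has been derived from them.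

The next compound is compound 3, `CCN(Cc1ccccc1Cl)C(=O)C1CCN(S(=O)(=O)c2ccc3[nH]ncc3c2)CC1`. It differs from compound 2 in one place: 1H-indazol-5-yl in place of 1H-indazol-6-yl on a sulfonyl sulfur. The 1H-indazol-5-yl on the sulfonyl sulfur is already present in compound 1, whose maximal response of 86% sits within the scatter of compound 2. With the change from 1H-indazol-6-yl to 1H-indazol-5-yl therefore no step beyond the scatter is expected, and the step of a number 5 percentage points lower from compound 2 to compound 3 (within the scatter) is estimated to be small in either direction. For compound 3 the expected maximal response is 88%, with a range from 72% to 100%.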

Compound 3, largest response reached (reported as percent of maximum), in percent of the reference or control that the assay uses: 78%
Compound 3: the middle estimate sits 10 percentage points above what was measured, and the stated range covers the measured number.
By their numbers in this assay, from the lowest: compounds 3, 1 and 2 (each within the scatter of the next, the first and the last beyond it).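

In this assay, within the data shown here, with the chloro group held constant, 1H-indazol-5-yl in place of 1H-indazol-6-yl on the sulfonyl sulfur gives a number 15 percentage points lower from compound 2 to compound 3 (beyond the scatter) and is the first step to clear the scatter. The two groups have the same atoms and the same counts of rings, donors and acceptors, so the way the indazole is joined to the sulfonyl sulfur is enough to separate compounds on this read-out, at modest size. With 1H-indazol-5-yl held constant, chloro in place of hydrogen on an aromatic carbon gives a number 8 percentage points lower from compound 1 to compound 3 (within the scatter) and therefore cannot be read as a real change, while no measurement at hand explains the difference between the two indazole attachments.

The compounds shown leave open whether chloro in place of hydrogen would also stay within the scatter with 1H-indazol-6-yl on the sulfonyl sulfur, since only one such pair can be read so far. Also open, going by these compounds, is how the maximal response would respond to a fluoro or methoxy group in place of chloro, or to a methyl group or longer chain in place of ethyl.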